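The source may report more compounds than this note shows. Statements on the series, on what has been measured and on what is new or still open speak of the compounds shown alone.

Measured so far in a functional assay on HCT-116 cells (Homo sapiens) for cytotoxicity, with a stated time of 3 days; on this read-out lower numbers stand for stronger inhibition and higher numbers for weaker inhibition: compound 1 `c1csc(-c2cc(-c3ccoc3)cc(-c3cccs3)n2)c1` with 50600 nM; compound 2 `Clc1ccc(-c2cc(-c3cccs3)nc(-c3cccs3)c2)o1` with 95500 nM.

For the measured compounds named here, compound 2 stands at the upper number of the pair, yet the one step seen, a 1.9-fold higher number from compound 1 to compound 2 (0.28 log units; within the scatter), lies within the scatter, so the two compounds are not separated on this assay. Compound 3 `Clc1ccc(-c2cc(-c3ccsc3)nc(-c3cccs3)c2)o1` differs from compound 2 by thiophen-3-yl in place of thiophen-2-yl on an aromatic carbon. Going by the values given here, no measured step involves this change, and the single step, a 1.9-fold higher number from compound 1 to compound 2 (0.28 log units; within the scatter), was itself flat. Compound 3 is therefore expected to stay near compound 2, with an estimated step of a 1.1-fold lower number from compound 2 to compound 3 (0.03 log units; within the scatter), and an estimated value of 90000 nM, ranging from 35000 nM to 230000 nM.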

Compound 3, half-maximal inhibitory concentration: > 100000 nM
Compound 3: only a limit was reported (the forecaster's own chance of this, stated with the estimate: 25%); at least 1.1-fold (0.04 log units) between middle value and limit.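

In this assay, the position next to the ring nitrogen now has its first reading, with thiophen-3-yl in place of thiophen-2-yl giving an at least 1.0-fold higher number from compound 2 to compound 3 (0.01 log units; that floor lies within the scatter). For compound 3, > 100000 nM is a limit of the assay, not a number. The change gives no sign of a lower number, but how far the number rises cannot be read: the limit of > 100000 nM in this assay, at which 1 of the 3 values shown sits.

Going by these compounds, it remains open whether an amine or a carboxylic acid in place of the thiophen-2-yl group would give a clearly lower number in this assay.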